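Sulfonyl aryl change from compound 1 to compound 3

The source may hold more compounds than are shown below. What is called first, only, known or untested is meant among the compounds shown, and "the series" means these compounds.

Compound 1 `CCc1ccc(S(=O)(=O)N[C@H]2CCN(CCCOc3ccc(C(=O)C4CC4)cc3)C2)cc1` is the reference point. Among the compounds with values here, in an assay on isolated protein for binding affinity to histamine H2 receptor (Homo sapiens) (on this read-out higher numbers stand for weaker inhibition and lower numbers for stronger inhibition), compound 1 gives 330 nM, the lowest of the two numbers measured so far. Its nearest neighbour is compound 2 `Cc1ccc(S(=O)(=O)N[C@H]2CCN(CCCOc3ccc(C(=O)C4CC4)cc3)C2)cc1`, which in this assay gives 380 nM; the step of a 1.2-fold higher number from compound 1 to compound 2 (0.06 log units; within the scatter) lies within the scatter. Compound 3 `O=C(c1ccc(OCCCN2CC[C@H](NS(=O)(=O)c3cccc(F)c3)C2)cc1)C1CC1` carries 3-fluorophenyl in place of 4-ethylphenyl on a sulfonyl sulfur. Within the data shown here, the only measured step, hydrogen in place of methyl on a saturated chain carbon bound to an aromatic carbon, bears on it only loosely: it shows that trimming the alkyl group on that ring leaves this assay unchanged within the scatter, but nothing measured covers losing the 4-ethyl group entirely or bringing in a 3-fluorophenyl. Without a directly relevant step, only a modest shift in this assay is expected, a 1.4-fold higher number from compound 1 to compound 3 (0.13 log units; within the scatter), with a wide range. Compound 3 is therefore estimated at 450 nM in this assay, within a range of 150 nM to 1500 nM.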

Compound 3, inhibition constant: 1600 nM
For compound 3 the middle estimate is 3.6-fold (0.55 log units) below the measured one, and the stated range ends below it.
By their numbers in this assay, from the lowest: compounds 1 and 2 (each within the scatter of the next); then compound 3.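

In this assay, the aryl group on the sulfonyl sulfur now shows a change beyond the scatter: 3-fluorophenyl in place of 4-ethylphenyl gives a 4.8-fold higher number from compound 1 to compound 3 (0.69 log units; beyond the scatter) and 3-fluorophenyl in place of 4-methylphenyl gives a 4.2-fold higher number from compound 2 to compound 3 (0.62 log units; beyond the scatter) in the same direction. The earlier step between the two alkyl groups (a 1.2-fold higher number from compound 1 to compound 2 (0.06 log units; within the scatter)) stayed within the scatter, so this position is not indifferent to every change of its aryl group, even though shortening the 4-alkyl group made no clear difference. No supporting evidence bears on the size of this shift.

The compounds shown do not separate the loss of the 4-alkyl group from the arrival of the fluorine. A plain phenyl or a 4-fluorophenyl on the sulfonyl sulfur would tell these two parts apart, and a 4-propylphenyl would test a longer chain.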